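This account rests on a few compounds, and the source may have more. Where it says the series, first, only, none or still open, it means among the compounds named here.

Measured in an ADME assay on HepG2 cells (Homo sapiens) for cytotoxicity, in the presence of a further agent that is not named here; a higher number here means a weaker inhibitor, a lower number a stronger inhibitor:
- Compound 1 `Cn1c(Cc2ccccc2C(F)(F)F)nc(C(=O)NCc2cccnc2)c(O)c1=O`: > 100000 nM (a limit)
- Compound 2 `CCn1c(Cc2ccccc2C(F)(F)F)nc(C(=O)NCc2ccccc2)c(O)c1=O`: > 100000 nM (a limit)
- Compound 3 `Cn1c(Cc2ccccc2C(F)(F)F)nc(C(=O)NCc2ccccc2F)c(O)c1=O`: > 100000 nM (a limit)

Not yet measured: compound 4 `Cn1c(Cc2ccccc2C(F)(F)F)nc(C(=O)NCc2ccccc2)c(O)c1=O`.

In this assay compound 3 has no numerical value, only the limit > 100000 nM. For the measured compounds named here, it stands with the other two compounds, as the series so far shows (the limit of > 100000 nM in this assay, at which 3 of the 3 values shown sit). None of the three goes against this.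

The change under consideration is hydrogen in place of fluoro on an aromatic carbon: the 2-fluorobenzyl group of compound 3 becomes the benzyl group of compound 4. Going by the values given here, the only measured step that bears on it is a step that the two limits leave unreadable from compound 1 to compound 3, where 2-fluorophenyl replaces pyridin-3-yl at the same end of the amide. Both ends of that step are limits, so it gives no size to carry over. Compound 2 also carries a benzyl group on the amide, and its value is likewise only a limit.

No measurable change is therefore expected in this assay, in either direction, and a further limit is the likely report. The expected step is a number no higher from compound 3 to compound 4 (the limit leaves the size open). The estimate for compound 4 is 100000 nM, with an expected range of 50000 nM to 200000 nM.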

Compound 4, half-maximal inhibitory concentration: > 100000 nM
Compound 4: a limit, no number; the forecaster's own chance of this, stated with the estimate: 90%; the middle value lies on the limit itself.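

In this assay compound 4 gives > 100000 nM, a limit and not a number. Its steps from compound 1, compound 2 and compound 3 cannot be read, since both ends of each are limits. The compounds shown leave open whether any of these changes alters the half-maximal inhibitory concentration at all, and how far each compound lies from this shared value: the limit of > 100000 nM in this assay, at which 4 of the 4 values shown sit.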